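Chain-end amine swap on a quinone N-oxide core

A few compounds are considered here, and "the series" means these few. Any claim that something is new, unique, unknown or untested is made for them only; others in the source may bear on it.

Measured compounds:
- compound 1 `O=C1c2c[n+]([O-])c3ccccc3c2C(=O)c2c1c1ccccc1n2CCCCN1CCCCC1`: 610 nM
- compound 2 `O=C1c2c[n+]([O-])c3ccccc3c2C(=O)c2c1c1ccccc1n2Cc1cn([C@H]2C[C@H](O)[C@@H](CO)O2)nn1`: 580 nM
- compound 3 `O=C1c2c[n+]([O-])c3ccccc3c2C(=O)c2c1c1ccccc1n2Cc1cn([C@@H]2O[C@H](CO)[C@@H](O)[C@H](O)[C@H]2O)nn1`: 650 nM

All three share the core of compound 1 and differ only in the substituent on the indole-type nitrogen. In a functional assay on MDA-MB-231 cells (Homo sapiens) for cytotoxicity, read by MTT assay, with a stated time of 72 h (a lower number here means a stronger inhibitor, a higher number a weaker inhibitor), compound 1 gives 610 nM; compound 2 gives 580 nM and compound 3 gives 650 nM. Compound 1 stands second of the three numbers, and both its neighbours lie within the scatter of it, so the three values are not distinguishable. Going by the values given here, the only measured step, a 1.1-fold higher number from compound 2 to compound 3 (0.05 log units; within the scatter), exchanges one sugar for another on a triazole nitrogen and also stays within the scatter.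

Compound 4 `O=C1c2c[n+]([O-])c3ccccc3c2C(=O)c2c1c1ccccc1n2CCCN1CCC(O)CC1` is not yet measured. It differs from compound 1 as follows: 4-hydroxypiperidin-1-yl in place of (piperidin-1-yl)methyl on a saturated chain carbon, three bonds along the chain from an aromatic nitrogen. No measured step touches the chain-end amine, so nothing shown speaks for or against this change; the one step that is known sits on a different part of the molecule and was flat. The only ground for an expectation is that every substituent change seen so far on this nitrogen has left this assay unmoved. The step of a 1.0-fold lower number from compound 1 to compound 4 (0.01 log units; within the scatter) is therefore expected to stay within the scatter. Compound 4 is estimated at 600 nM, with a range of 300 nM to 1200 nM.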

Compound 4, half-maximal inhibitory concentration: 280 nM
Beside the measured number, compound 4's estimate is 2.1-fold (0.33 log units) above it; measured number outside the range, below it.
By their numbers in this assay, from the lowest: compound 4; then compounds 2, 1 and 3 (each within the scatter of the next).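

In this assay, going from 4-(piperidin-1-yl)butyl to 3-(4-hydroxypiperidin-1-yl)propyl gives a 2.2-fold lower number from compound 1 to compound 4 (0.34 log units; beyond the scatter), the only step shown that lies beyond the scatter, so the substituent on this nitrogen is not always silent, although the step is modest. The step carries two differences at once, since the chain changes from butyl to propyl and a hydroxy group enters on the piperidine ring, and the pair cannot assign it to either one. No data shown here bear on the reason for this step.

The compounds shown leave open which of the two differences carries the step, and a 3-(piperidin-1-yl)propyl or a 4-(4-hydroxypiperidin-1-yl)butyl substituent on the same nitrogen would separate them. Also open, from the compounds shown here alone, is whether a morpholin-4-yl or 4-methoxypiperidin-1-yl group at the chain end would follow compound 4 or stay with compound 1.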